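A few compounds are considered here, and "the series" means these few. Any claim that something is new, unique, unknown or untested is made for them only; others in the source may bear on it.

Compound 2 `C[C@H](NC(=O)c1ccc(Cl)cc1O)C(=O)Nc1ccc(Cl)c(Cl)c1` stands at a limit in a functional assay on MCF7 cells (Homo sapiens) for cytotoxicity, with a stated time of 72 h; a higher number here means a weaker inhibitor, a lower number a stronger inhibitor. In this assay compound 2 gives only a limit, > 12500 nM, so no number places compound 2 among the others; it sits at the limit of > 12500 nM in this assay, at which 1 of the 3 values shown sits. Compound 1 `CC(C)[C@H](NC(=O)c1ccc(Cl)cc1O)C(=O)Nc1ccc(Cl)c(Cl)c1` also gives only a limit in this assay, > 10000 nM, which is the limit of > 10000 nM in this assay, at which 1 of the 3 values shown sits. The step that the two limits leave unreadable from compound 1 to compound 2 is thus left unreadable; its change is methyl in place of isopropyl on a saturated chain carbon bound to an amide-type nitrogen and a carbonyl carbon. Compound 3 `CC(C)(C)[C@H](NC(=O)c1cc(Cl)ccc1O)C(=O)Nc1cccc(C(F)(F)F)c1` differs from compound 2 in more than one place; in this assay compound 3 gives 8800 nM. The change to compound 4 `C[C@H](NC(=O)c1ccc(Cl)cc1O)C(=O)Nc1ccc(Cl)cc1` is hydrogen in place of chloro on an aromatic carbon; seen one bond further out, a 3,4-dichlorophenyl becomes a 4-chlorophenyl. Going by the values given here, no measured step covers this change, and the one measured step is unreadable. Compound 4 is therefore expected to show no step beyond the scatter, a step that the limit leaves unreadable from compound 2 to compound 4. Compound 4 is estimated at 20000 nM, within 7000 nM to 60000 nM, and is likely to come back as a limit again.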

Compound 4, half-maximal inhibitory concentration: > 10000 nM
Compound 4: a limit, no number; the forecaster's own chance of this, stated with the estimate: 70%; the middle value is on the limit's open side.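

In this assay compound 2 and compound 4 both give only limits, so the step between them cannot be read. The compounds shown leave open whether going from 3,4-dichlorophenyl to 4-chlorophenyl changes the half-maximal inhibitory concentration at all.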